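A Larger Sulfonyl Aryl Group on Compound 2

A few compounds are considered here, and "the series" means these few. Any claim that something is new, unique, unknown or untested is made for them only; others in the source may bear on it.

In an assay on Sf9 cells for inhibition of mitogen-activated protein kinase kinase kinase 20 (Homo sapiens), read by ADP-Glo, with a stated time of 30 min (a higher number here means a weaker inhibitor, a lower number a stronger inhibitor), compound 2 (`COc1n[nH]c2ncc(-c3cn(-c4c(F)ccc(NS(=O)(=O)c5ccccc5)c4F)nn3)cc12`) gives 3.8 nM, the lower of the two numbers recorded so far. Compound 1 (`COc1n[nH]c2ncc(-c3cn(-c4cccc(NS(=O)(=O)c5cccc(Cl)c5)c4)nn3)cc12`) gives 24.7 nM in this assay, a gap from compound 2 that lies beyond the scatter. Compound 3 (`COc1n[nH]c2ncc(-c3cn(-c4c(F)ccc(NS(=O)(=O)c5cccc6ccccc56)c4F)nn3)cc12`) has not yet been measured. It differs from compound 2 by naphthalen-1-yl in place of phenyl on a sulfonyl sulfur. Among the compounds with values here, no measured pair shows this change, so its effect is uncertain; a step of modest size in either direction, or none beyond the scatter, is expected. Compound 3 is estimated at 5 nM, within 1.5 nM to 20 nM. The step of a 1.3-fold higher number from compound 2 to compound 3 (0.12 log units; within the scatter) is expected to be small.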

Compound 3, half-maximal inhibitory concentration: 4.2 nM
Compound 3: middle estimate off by 1.2-fold (0.08 log units), on the high side; measured number inside the range.
By their numbers in this assay, from the lowest: compounds 2 and 3 (each within the scatter of the next); then compound 1.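

With naphthalen-1-yl in place of phenyl on the sulfonyl sulfur, this assay shows a 1.1-fold higher number from compound 2 to compound 3 (0.04 log units; within the scatter), so compound 2 and compound 3 cannot be told apart. The earlier compounds shown here did not show that this position accepts the larger naphthalen-1-yl group with no change beyond the scatter. No evidence is available that explains this result.

From the compounds shown here alone, whether an amine, a carboxylic acid or a longer chain on the sulfonyl sulfur would give a similar number remains open. So does whether naphthalen-1-yl would have the same effect without the two fluorines of compound 2.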